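The source may hold more compounds than are shown below. What is called first, only, known or untested is meant among the compounds shown, and "the series" means these compounds.

Compound 1 `CCOC(=O)C1=C(C)NC(SCc2nnc(-c3ccccc3)o2)=NC1c1ccc(Cl)cc1` and compound 2 `CCOC(=O)C1=C(C)NC(SCc2nnc(-c3ccc(Cl)cc3)o2)=NC1c1ccccc1Cl` share one core and differ only in where chlorine sits on their two benzene rings. In a functional assay on MOLT-4 cells (Homo sapiens) for inhibition, read by MTT assay, with a stated time of 24 h (on this read-out higher numbers stand for weaker inhibition and lower numbers for stronger inhibition), compound 1 gives 344000 nM, and in this assay compound 2 gives 255000 nM; the gap between these two numbers lies within the usual scatter of repeated measurements, so the two compounds cannot be told apart on this read-out. Compound 3 `CCOC(=O)C1=C(C)NC(SCc2nnc(-c3ccc(Cl)cc3)o2)=NC1c1ccc(Cl)cc1` has not yet been measured. It is compound 1 with one change: chloro in place of hydrogen on an aromatic carbon. Among the measured compounds shown here, no measured pair shows this exact change on its own, so there is no direct guide to its size. Because compound 1 gives 344000 nM and compound 2 gives 255000 nM with two chlorines in place, the step from compound 1 to compound 3 is expected to be small, a 1.2-fold lower number from compound 1 to compound 3 (0.07 log units; within the scatter), not beyond the scatter in either direction. Compound 3 is therefore estimated at 290000 nM, within a range from 120000 nM to 700000 nM.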

Compound 3, half-maximal inhibitory concentration: 623 nM
Estimate against measurement, compound 3: 470-fold (2.67 log units) above; the measured number lies below the stated range.
By their numbers in this assay, from the lowest: compound 3; then compounds 2 and 1 (each within the scatter of the next).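

In this assay, the change from phenyl to 4-chlorophenyl, with the chloro para to a large group, gives a 550-fold lower number from compound 1 to compound 3 (2.74 log units; beyond the scatter), so one added atom at this position can matter enormously, which the close values of the first two compounds gave no hint of. Moving the chlorine on the other benzene ring, with 4-chlorophenyl in place of 2-chlorophenyl on a saturated ring carbon, gives a 410-fold lower number from compound 2 to compound 3 (2.61 log units; beyond the scatter), so among these three compounds the low number appears only when both rings carry 4-chlorophenyl. Nothing available here explains a jump of this size.

On these data alone, it remains open whether another group at the same position, such as bromo, methoxy or an amine, would keep the low number. As far as these compounds go, it is also open whether the ethyl ester on the shared core could give way to a carboxylic acid without losing it.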